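Chloro-for-methyl exchange on the pyridyl ether of compound 2

This account rests on a few compounds, and the source may have more. Where it says the series, first, only, none or still open, it means among the compounds named here.

Among the measured compounds shown here, compound 2 `Cc1ccc(C)c(Oc2ccc3nc(COc4cccc(C(=O)O)c4)n(C)c3c2)n1` gives 1.4 in a physicochemical assay for lipophilicity, read by LC-MS, in phosphate buffer, measured as octanol-water partition, with a stated time of 30 min, at pH 7.4, tested at 200 mM (on this read-out higher numbers stand for higher lipophilicity and lower numbers for lower lipophilicity), the higher of the two numbers so far; its nearest neighbour, compound 1 `Cn1c(COc2cccc(C(=O)O)c2)nc2ccc(Oc3ccc(Cl)cn3)cc21`, gives 1.2. For the measured compounds named here, the one measured step, a number 0.20 log units higher from compound 1 to compound 2 (within the scatter), is within the scatter. Compound 3 `Cc1cc(Cl)cnc1Oc1ccc2nc(COc3cccc(C(=O)O)c3)n(C)c2c1` differs from compound 2 by 5-chloro-3-methylpyridin-2-yl in place of 3,6-dimethylpyridin-2-yl on an oxygen on an aromatic ring. That change partly reverses the step from compound 1 to compound 2, which bears on it but was itself small, so no step beyond the scatter is expected in this assay, with a number 0.10 log units lower from compound 2 to compound 3 (within the scatter) the estimated size. Compound 3 is therefore expected to read 1.3, within 0.9 to 1.7.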

Compound 3, distribution coefficient: 1.8
For compound 3 the middle estimate is 0.50 log units below the measured one; measured number above the stated range.
By their numbers in this assay, from the lowest: compounds 1 and 2 (each within the scatter of the next); then compound 3.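

In this assay, among the compounds shown here, methyl in place of hydrogen on an aromatic carbon of the 5-chloropyridin-2-yl group gives a number 0.60 log units higher from compound 1 to compound 3 (beyond the scatter) and is the clearest single change so far. 5-Chloro-3-methylpyridin-2-yl in place of 3,6-dimethylpyridin-2-yl gives a number 0.40 log units higher from compound 2 to compound 3 (beyond the scatter), so the substituents on this ring can move the read-out, which the earlier pair did not show. Nothing at hand accounts for either step. Still open, from the compounds shown here alone, is whether an ethyl group or a methoxy group on that carbon would read like methyl. Also open, going by these compounds, is how an amine in place of the chlorine would read.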